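Quinazoline anilide series: ester replaced by glycolamide, prospect

The compounds below may be only part of what the source reports. "The series", "measured", "known", "first", "only" and "open" are said of these compounds alone.

Compound 1 `CCOc1cc2ncnc(Nc3ccc(F)c(Cl)c3)c2cc1OC(=O)CSc1ncccn1` is the stronger of the two measured compounds in a functional assay on NCI-H1975 cells (Homo sapiens) for inhibition, read by MTT assay, with a stated time of 72 h (a lower number here means a stronger inhibitor, a higher number a weaker inhibitor), where compound 1 gives 3600 nM. Compound 2 `CCOc1cc2ncnc(Nc3ccc(F)c(Cl)c3)c2cc1OC(=O)CSc1nc2ccccc2s1` gives 9800 nM in this assay, and the step of a 2.7-fold higher number from compound 1 to compound 2 (0.43 log units; beyond the scatter) shows that changing the aryl on the sulfur already costs potency.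

Compound 3 `CCOc1cc2ncnc(Nc3ccc(F)c(Cl)c3)c2cc1NC(=O)CO` carries a different change: ((hydroxymethyl)carbonyl)amino in place of ((((pyrimidin-2-yl)sulfanyl)methyl)carbonyl)oxy on an aromatic carbon. For the measured compounds named here, no measured step touches this position in the same way, since the only step available varies the group on the sulfur while the ester linkage is kept; it therefore gives no direct guide to removing the whole pyrimidinylsulfanyl acetyl and putting in the glycolamide. Going by the values given here, with the sole measured change at this site being a loss, a modest loss is expected, worded as a 1.4-fold higher number from compound 1 to compound 3 (0.14 log units; within the scatter), though with wide uncertainty. Compound 3 is expected to give 5000 nM in this assay, within a range of 1500 nM to 16000 nM.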

Compound 3, half-maximal inhibitory concentration: > 10000 nM
Compound 3 gave a limit, no number; the forecaster's own chance of this, stated with the estimate: 10%; at least 2.0-fold (0.30 log units) between middle value and limit.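

Compound 3 gives only a limit, not a number, in this assay: the limit of > 10000 nM in this assay, at which 1 of the 3 values shown sits. The change at this aromatic carbon, ortho to an ethoxy group, gives an at least 2.7-fold higher number from compound 1 to compound 3 (0.44 log units; beyond the scatter), so exchanging the whole ((((pyrimidin-2-yl)sulfanyl)methyl)carbonyl)oxy group for ((hydroxymethyl)carbonyl)amino also costs potency, and the position responds to more than the aryl on the sulfur. In this change, the ring, the sulfur and the ester link all leave together, so the step cannot assign the loss to any one of them.

Still open, as far as these compounds go, is whether an amide link keeping the pyrimidin-2-yl sulfanyl group would retain the potency of compound 1. Also open, from the compounds shown here alone, is how a small amide carrying a dimethylamino group or a carboxylic acid in place of the hydroxyl would compare with compound 3.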